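The compounds below may be only part of what the source reports. "The series", "measured", "known", "first", "only" and "open" are said of these compounds alone.

Measured compounds in an assay for inhibition of beta-glucuronidase (Bos taurus), read by spectrophotometry, with a stated time of 30 min; on this read-out lower numbers stand for stronger inhibition and higher numbers for weaker inhibition: compound 1, `COc1ccc(/C=C/C(=O)OCCn2c([N+](=O)[O-])cnc2C)cc1`, gives 31100 nM. Compound 2, `Cc1ncc([N+](=O)[O-])n1CCOC(=O)c1cccc(Cl)c1`, gives 16300 nM. Compound 3, `Cc1ncc([N+](=O)[O-])n1CCOC(=O)c1ccc(Cl)c(Cl)c1`, gives 3600 nM.

Compound 2 stands second highest of the three numbers; compound 1 lies within the scatter of it, while compound 3 shows a 4.5-fold lower number from compound 2 to compound 3 (0.66 log units; beyond the scatter), a modest change. Compound 4, `Cc1ncc([N+](=O)[O-])n1CCOC(=O)c1ccc(F)cc1`, differs from compound 2 by 4-fluorophenyl in place of 3-chlorophenyl on a carbonyl carbon. Within the data shown here, the only measured step bearing on this is the one from compound 2 to compound 3, where adding chloro to the ring lowered the number. Here the chloro is removed and fluorine enters elsewhere, so no step beyond the scatter is firmly expected in this assay. Compound 4 is estimated at 25000 nM (range 10000 nM to 70000 nM), an expected 1.5-fold higher number from compound 2 to compound 4 (0.19 log units; within the scatter).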

Compound 4, half-maximal inhibitory concentration: 12400 nM
Compound 4: middle estimate off by 2.0-fold (0.30 log units), on the high side, and the stated range covers the measured number.
By their numbers in this assay, from the lowest: compound 3; then compounds 4, 2 and 1 (each within the scatter of the next, the first and the last beyond it).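

In this assay the change to 4-fluorophenyl in place of 3-chlorophenyl on a carbonyl carbon gives a 1.3-fold lower number from compound 2 to compound 4 (0.12 log units; within the scatter) and so leaves the number within the scatter. This position therefore accepts a change of both the halogen and its place on the ring, and the 3-chlorophenyl group is not needed to hold the number of compound 2. No measurement at hand gives a reason for this result.

The halogen and its place changed together, so their contributions cannot be separated here. As far as these compounds go, what an unsubstituted phenyl, or an amine or hydroxyl on that ring, would give remains open.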